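This account rests on a few compounds, and the source may have more. Where it says the series, first, only, none or still open, it means among the compounds named here.

Of the compounds shown here, three that share a core have been measured in a functional assay on NCI-H460 cells (Homo sapiens) for inhibition, read by MTT assay, with a stated time of 4 days; a lower number here means a stronger inhibitor, a higher number a weaker inhibitor. Compound 1 `COc1cc(NC(C)CCCNC(=O)NNC(=O)Nc2ccc(Cl)c(C(F)(F)F)c2)c2ncccc2c1` gives 13000 nM, the higher of the two actual numbers and so the weaker inhibitor of that pair. Compound 3 `COc1cc(NC(C)CCCNC(=O)NNC(=O)NCCNC(c2ccccc2)(c2ccccc2)c2ccccc2)c2ncccc2c1` gives 4000 nM, a lower number, and the gap lies beyond the usual scatter. Compound 2 `COc1ccc(/C(=N/NC(=O)NCCCC(C)Nc2cc(OC)cc3cccnc23)c2ccccc2)cc1` is reported as > 100000 nM, which is a limit of the assay and not a number.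

Compound 4 `COc1cc(NC(C)CCCNC(=O)NNC(=O)N(CCO)CCO)c2ncccc2c1` has not yet been measured. It differs from compound 1 in one place: bis(2-hydroxyethyl)amino in place of (4-chloro-3-(trifluoromethyl)phenyl)amino on a carbonyl carbon. Here, bis(2-hydroxyethyl)amino stands in place of (4-chloro-3-(trifluoromethyl)phenyl)amino on a carbonyl carbon, so the aromatic ring of that group is lost. For the measured compounds named here, no measured pair shows this change directly, so the expectation is loose. Starting from compound 1 at 13000 nM, a moderate step towards a higher number, meaning weaker inhibition, is expected in this assay. For compound 4, this assay may report only a limit. The expected change is a 3.1-fold higher number from compound 1 to compound 4 (0.49 log units; beyond the scatter). For compound 4, the estimate is 40000 nM, with an expected range of 10000 nM to 100000 nM.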

Compound 4, half-maximal inhibitory concentration: > 100000 nM
Compound 4 gave a limit, no number; the forecaster's own chance of this, stated with the estimate: 35%; middle value at least 2.5-fold (0.39 log units) from the limit.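

Replacing (4-chloro-3-(trifluoromethyl)phenyl)amino with bis(2-hydroxyethyl)amino on the carbonyl carbon gives an at least 7.6-fold higher number from compound 1 to compound 4 (0.88 log units; beyond the scatter) in this assay, the only direct reading of a one-place change among the compounds shown. At this place, then, this ring-free group with two hydroxyethyl chains does not keep even the modest inhibition of compound 1. The step is a minimum and not a measured size, as compound 4 gave a limit of the assay and not a number, and that limit recurs in this small set: the limit of > 100000 nM in this assay, at which 2 of the 4 values shown sit.

For the compounds shown here, the single step does not separate the loss of the aromatic ring from the arrival of the two hydroxyl groups. A plain phenylamino group, without chlorine or trifluoromethyl, and a diethylamino group, without the hydroxyl groups, would each test one of these changes alone.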